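The source may report more compounds than this note shows. Statements on the series, on what has been measured and on what is new or still open speak of the compounds shown alone.

Compound 1 `CCN(CC)CCC(c1ccccc1)c1ccccc1` gives 197 nM in an assay on ileum with muscarinic acetylcholine receptor M3 (Cavia porcellus) as the target; a higher number here means a weaker inhibitor, a lower number a stronger inhibitor; compound 2 `NC(=O)C(CCn1ccnc1)(c1ccccc1)c1ccccc1` gives 5.07 nM; compound 3 `CC(C)c1nccn1CCC(C(N)=O)(c1ccccc1)c1ccccc1` gives 1.8 nM.

Compound 2 stands second highest of the three numbers in this assay: compound 1 lies far higher, compound 3 somewhat lower. Compound 4 `Cc1ncn(CCC(C(N)=O)(c2ccccc2)c2ccccc2)c1C` differs from compound 2 by 4,5-dimethyl-1H-imidazol-1-yl in place of 1H-imidazol-1-yl on a saturated chain carbon, three bonds along the chain from two aromatic carbons and a carbonyl carbon. For the measured compounds named here, the only measured step that bears on this is a 2.8-fold lower number from compound 2 to compound 3 (0.45 log units; beyond the scatter), likewise a substitution on an aromatic carbon of the shared core; a step of comparable size in the same direction is expected here, with no other step to check it against. Compound 4 is therefore expected at 2.5 nM, with a range of 1 nM to 6 nM. The expected step is a 2.0-fold lower number from compound 2 to compound 4 (0.31 log units; beyond the scatter).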

Compound 4, antagonist equilibrium constant: 2.7 nM
Estimate against measurement, compound 4: 1.1-fold (0.03 log units) below; low and high end bracket the measured number.
By their numbers in this assay, from the lowest: compounds 3, 4 and 2 (each within the scatter of the next, the first and the last beyond it); then compound 1.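

In this assay the dimethyl change gives a 1.9-fold lower number from compound 2 to compound 4 (0.27 log units; within the scatter) and so cannot be told apart from the unsubstituted ring at this position. Against the 2-isopropyl group, the change gives a 1.5-fold higher number from compound 3 to compound 4 (0.18 log units; within the scatter) and is equally unresolved, so compound 4 sits within the scatter of both neighbours, while a 2.8-fold lower number from compound 2 to compound 3 (0.45 log units; beyond the scatter) remains the only step here that exceeds it. No measurement available here accounts for these numbers.

Still open, as far as these compounds go, is whether a single methyl on the ring gives a step beyond the scatter. Also open, from the compounds shown here alone, is how an amine or carboxylic acid on the ring, or a longer chain to the shared core, would read.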